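The source may hold more compounds than are shown below. What is called first, only, known or untested is meant among the compounds shown, and "the series" means these compounds.

In an ADME assay on RAW264.7 cells (Mus musculus) for cytotoxicity, read by MTT assay, with a stated time of 24 h (on this read-out higher numbers stand for lower toxicity in this test and lower numbers for higher toxicity in this test), the measured compounds are these:
- compound 1 `CC/C=C\C[C@H]1C(=O)C=C[C@H]1CC(=O)OCC` gives 146 uM
- compound 2 `CC/C=C\C[C@H]1C(=O)C=C[C@H]1CC(=O)OCCOC` gives 160 uM
- compound 3 `CC/C=C\C[C@H]1C(=O)C=C[C@H]1CC(=O)OC(C)CC` gives 53 uM

Going by the values given here, compound 3 stands lowest of the three, so it is the most toxic in this assay so far. Compound 4 `CC/C=C\C[C@H]1C(=O)C=C[C@H]1CC(=O)OC1CCCCC1` carries cyclohexyl in place of sec-butyl on an oxygen next to a carbonyl group. Among the compounds with values here, two measured steps bear on this change, as both arrive at the sec-butyl group: a 2.8-fold lower number from compound 1 to compound 3 (0.44 log units; beyond the scatter) and a 3.0-fold lower number from compound 2 to compound 3 (0.48 log units; beyond the scatter). Both are modest and downward. By contrast, a 1.1-fold higher number from compound 1 to compound 2 (0.04 log units; within the scatter) shows no real change. Within the data shown here, no measured step brings in a ring, so the comparison is only a rough guide. A further small drop is expected, since the incoming group again holds only carbon and is larger by the count above. The estimated step is a 1.8-fold lower number from compound 3 to compound 4 (0.25 log units; within the scatter), similar to or smaller than those two. Compound 4 is expected at 30 uM, with an estimated range from 12 uM to 70 uM in this assay.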

Compound 4, half-maximal toxic concentration: 31 uM
Beside the measured number, compound 4's estimate is 1.0-fold (0.01 log units) below it; the measured number falls inside the stated range.
By their numbers in this assay, from the lowest: compounds 4 and 3 (each within the scatter of the next); then compounds 1 and 2 (each within the scatter of the next).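

In this assay the ring cannot be told apart from the open chain: cyclohexyl in place of sec-butyl on an oxygen next to a carbonyl group gives a 1.7-fold lower number from compound 3 to compound 4 (0.23 log units; within the scatter) and so brings in a ring without a clear shift. Cyclohexyl does stand apart from the other two groups at this position, with a 4.7-fold lower number from compound 1 to compound 4 (0.67 log units; beyond the scatter) against ethyl and a 5.2-fold lower number from compound 2 to compound 4 (0.71 log units; beyond the scatter) against 2-methoxyethyl, the two widest steps among these compounds. No measurement shown here explains these differences.

Still open, going by these compounds, is whether phenyl or a longer chain such as octyl on this same oxygen would lower the number further or leave it where compound 4 stands. Also open is how a 2-aminoethyl group, which carries an amine, would fit among these compounds.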